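Extending a Hydroxy Chain on Two Related Cores

A few compounds are considered here, and "the series" means these few. Any claim that something is new, unique, unknown or untested is made for them only; others in the source may bear on it.

Measured compounds:
compound 1, `COc1ccc2cc(CO)oc(=O)c2c1`, 49.2 ug/mL
compound 2, `COc1ccc2cc(CCCO)oc(=O)c2c1`, 25.9 ug/mL
compound 3, `COc1ccc2c(c1)C(=O)OC(CO)C2`, 175 ug/mL

In a functional assay on PC-3 cells (Homo sapiens) for antiproliferative activity, read by sulforhodamine B assay, with a stated time of 48 h (a lower number here means a stronger inhibitor of growth, a higher number a weaker inhibitor of growth), compound 1 gives 49.2 ug/mL, while compound 2 gives 25.9 ug/mL. The two differ by one change, (2-hydroxyethyl in place of hydroxy on a saturated chain carbon bound to an aromatic carbon), and this change made a step of a 1.9-fold lower number from compound 1 to compound 2 (0.28 log units; within the scatter). Compound 3 gives 175 ug/mL in this assay and stands highest of the three numbers; how its core differs from the core of compound 1 is not broken down here, and the values alone show that compound 3 lies beyond the scatter from both compound 1 and compound 2.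

The unmeasured compound 4, `COc1ccc2c(c1)C(=O)OC(CCCO)C2`, carries the same kind of change on the core of compound 3: 2-hydroxyethyl in place of hydroxy on a saturated chain carbon bound to a saturated ring carbon. Going by the values given here, the change itself matches the one from compound 1 to compound 2, but the place differs: there the chain carbon is bound to an aromatic carbon, here to a saturated ring carbon, so the two changes are of the same kind rather than the same.

Since the earlier step of a 1.9-fold lower number from compound 1 to compound 2 (0.28 log units; within the scatter) lay within the scatter, the step from compound 3 to compound 4 is expected to be similar, a 1.6-fold lower number from compound 3 to compound 4 (0.20 log units; within the scatter), an expectation that rests on that one pair only. Compound 4 is therefore estimated at 110 ug/mL in this assay, with a plausible range from 50 ug/mL to 250 ug/mL.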

Compound 4, concentration for 50% growth inhibition: 70.7 ug/mL
Beside the measured number, compound 4's estimate is 1.6-fold (0.19 log units) above it; measured number inside the range.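

On the core of compound 3, going from hydroxymethyl to 3-hydroxypropyl gave in this assay a 2.5-fold lower number from compound 3 to compound 4 (0.39 log units; beyond the scatter). Going by these compounds alone, this pair and the pair on the core of compound 1 are the only two examples of the change, so they show no general rule for the series, and they do not show why the change acts as it does or that it would carry over to any further core. Within those limits, the step on the core of compound 3 passes the scatter while the earlier step does not, yet the two steps cannot be told apart, so the change carried from one core to the other with no measurable difference in the size of its step: the same change on two cores in this assay, a 1.9-fold lower number (0.28 log units; within the scatter) from compound 1 to compound 2 and a 2.5-fold lower number (0.39 log units; beyond the scatter) from compound 3 to compound 4, 1.3-fold (0.11 log units) apart, within the scatter of two such steps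

The compounds shown leave open whether the step continues with a longer chain than 3-hydroxypropyl or stops there, since only the two chain lengths appear on each core. They also leave open what happens on either core when an amine or a carboxylic acid takes the place of the hydroxy at the end of the chain.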